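Swapping isopropyl for benzyl in a cyclic depsipeptide

The compounds below may be only part of what the source reports. "The series", "measured", "known", "first", "only" and "open" are said of these compounds alone.

The measured compounds:
compound 1, `CCC[C@H]1NC(=O)c2csc(n2)[C@H](C)NC(=O)[C@H](C(C)C)N(C)C(=O)[C@H](Cc2ccccc2)N(C)C(=O)[C@H](C)OC(=O)[C@@H]1C`, 5000 nM
compound 2, `CCC[C@H]1NC(=O)c2csc(n2)[C@H](C)NC(=O)[C@H](C(C)C)N(C)C(=O)[C@H](Cc2ccc(O)cc2)N(C)C(=O)[C@H](C)OC(=O)[C@@H]1C`, 5000 nM

Both were tested in a functional assay on LoVo cells (Homo sapiens) for cytotoxicity; a lower number here means a stronger inhibitor, a higher number a weaker inhibitor. Compound 2, with a hydroxy in place of hydrogen on an aromatic carbon, stands level with compound 1, as no change at the digits printed from compound 1 to compound 2 (within the scatter) shows; its nearest neighbour in the set is compound 1, and the two sit together at the weaker end of what the assay reports.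

Compound 3, `CCC[C@H]1NC(=O)c2csc(n2)[C@H](C)NC(=O)[C@H](Cc2ccccc2)N(C)C(=O)[C@H](Cc2ccc(O)cc2)N(C)C(=O)[C@H](C)OC(=O)[C@@H]1C`, is not yet measured. It differs from compound 2 as follows: benzyl in place of isopropyl on a saturated ring carbon. Going by the values given here, the only measured step, from compound 1 to compound 2, concerns a different place and a different kind of change, so it gives no direct guide to the size of this one; it shows merely that one change elsewhere on the shared core left the value unchanged within the scatter. Among the compounds with values here, with no measured step bearing on the replacement itself, the expectation for compound 3 rests on the two flat measured values, and is that the step of no change at the digits printed from compound 2 to compound 3 (within the scatter) is small, in either direction, with a wide range to allow for the unknown. Compound 3 is therefore estimated at 5000 nM, between 1500 nM and 15000 nM.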

Compound 3, half-maximal inhibitory concentration: 5000 nM
Compound 3: middle estimate and measured number agree at the digits printed; the measured number falls inside the stated range.
By their numbers in this assay, from the lowest: compounds 1, 2 and 3 (each within the scatter of the next).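

In this assay, benzyl in place of isopropyl on a saturated ring carbon of the 19-membered ring gives no change at the digits printed from compound 2 to compound 3 (within the scatter), so this carbon, unlike the aromatic carbon of the earlier step, has now been tested directly. The group entering here is clearly larger than the one leaving, with 7 heavy atoms and a six-membered aromatic ring in place of 3 heavy atoms and no ring, yet compound 3 stands level with compound 2, so on the core of compound 2 this position accepts that swap without a reading beyond the scatter. Going by these compounds alone, nothing measured here explains why the two compounds read alike, and the result describes only this one swap on this one core.

On these data alone, whether another group on this carbon, such as a longer chain or a side chain ending in an amine or a carboxylic acid, would move the reading in this assay remains open. Also open, as far as these compounds go, is whether benzyl at this carbon would read the same on the core of compound 1, which has no hydroxy on its aromatic ring.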